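A few compounds are considered here, and "the series" means these few. Any claim that something is new, unique, unknown or untested is made for them only; others in the source may bear on it.

Measured so far:
compound 1, `CCc1nc2c(OCc3ccccc3)cccn2c1N`, 83%
compound 2, `Cc1nc2ccc(CCc3ccccc3)cn2c1N`, 52%
compound 3, `Cc1nc2c(OCc3ccccc3)cccn2c1CN`, 46%

All three numbers come from a functional assay on the whole organism with Rattus norvegicus as the target, at a dose of 40 mg/kg by the intraperitoneal route; a higher number here means more inhibition at the dose given (going by the name of the read-out), a lower number less inhibition. Compound 3 has the lowest of the three numbers. Its nearest neighbour is compound 2, whose number lies within the usual scatter of repeated measurements, so the two cannot be told apart on these data. Compound 1 is the furthest away, and its number stands well beyond the scatter above that of compound 3; this is the only clear gap among the three. No pair of these compounds differs in a single place, so no measured step can guide the next one.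

Compound 4, `CCNc1c(C)nc2c(OCc3ccccc3)cccn12`, has not yet been measured. It differs from compound 3 in one place: ethylamino in place of aminomethyl on an aromatic carbon. The amine thus moves from a carbon chain onto the ring carbon itself, and the chain grows by one carbon. Within the data shown here, with no measured step to lean on, only a cautious expectation is possible. Compound 4 is expected to give 60% in this assay. For compound 4 the expected range runs from an estimated 35% to an estimated 85%. The expected step of a number 14 percentage points higher from compound 3 to compound 4 (beyond the scatter) is upward, of a size that may only just pass beyond the scatter.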

Compound 4, a percentage reported as inhibition, in the whole organism at one dose (the size of the read-out at that dose, not a potency): 95%
Estimate against measurement, compound 4: 35 percentage points below, and the stated range ends below it.
By their numbers in this assay, from the lowest: compounds 3 and 2 (each within the scatter of the next); then compound 1; then compound 4.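

In this assay, among these compounds, replacing aminomethyl with ethylamino on this aromatic carbon of the five-membered ring gives a number 49 percentage points higher from compound 3 to compound 4 (beyond the scatter) as a large step, the only step between compounds differing in one place here. It shows that this position is far from indifferent to what it carries: a swap of only two heavy atoms for three, both groups holding a nitrogen, is enough to separate the two compounds well beyond the scatter. Both groups have the same counts of hydrogen-bond donors and acceptors, no ring and no net charge, so these counts do not distinguish them, and no measured information on the compounds accounts for the step.

This single change alters two things at once, since the nitrogen now sits directly on the ring carbon and the group has one more carbon, and the data cannot say which of these matters. Methylamino or propylamino on this same carbon would help separate the two, while a longer chain such as butylamino would show how far the chain can grow at this position.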